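A few compounds are considered here, and "the series" means these few. Any claim that something is new, unique, unknown or untested is made for them only; others in the source may bear on it.

Measured so far:
compound 1 `N#Cc1ccc(Nc2nc(Oc3ccc(Cl)cc3Cl)c3ccccc3n2)cc1` — 32000 nM
compound 2 `COc1cc(C#N)cc(Cl)c1Oc1nc(Nc2ccc(C#N)cc2)nc2ccccc12` — 220000 nM

In an ADME assay on MT4 cells (Homo sapiens) for cytotoxicity, read by MTT assay, with a stated time of 4 days (a lower number here means that less compound is tolerated, a higher number that more compound is tolerated), compound 1 gives 32000 nM, the lower of the two numbers; compound 2 gives 220000 nM, and the gap between them lies beyond the usual scatter. Compound 3 `N#Cc1ccc(Nc2nc(Oc3ccc(Cl)cc3)c3ccccc3n2)cc1` differs from compound 1 in one place: hydrogen in place of chloro on an aromatic carbon. Among the compounds with values here, no measured pair shows this change, so the size of the step is not known from the data. The expected step from compound 1 to compound 3 is small, a 1.3-fold higher number from compound 1 to compound 3 (0.10 log units; within the scatter), with no clear direction beyond the scatter. Compound 3 is expected to give 40000 nM, within the range 15000 nM to 120000 nM.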

Compound 3, half-maximal cytotoxic concentration: 198000 nM
For compound 3 the middle estimate is 5.0-fold (0.69 log units) below the measured one; measured number outside the range, above it.
By their numbers in this assay, from the lowest: compound 1; then compounds 3 and 2 (each within the scatter of the next).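

In this assay, going from 2,4-dichlorophenyl to 4-chlorophenyl on the shared core gives a clear step (a 6.2-fold higher number from compound 1 to compound 3 (0.79 log units; beyond the scatter)), and this step lies beyond the scatter. The chloro group ortho to a large group therefore counts at this place, which compound 1 and compound 2 alone could not show, as they offered no single change to read. Nothing available explains the size of this step. The compounds shown leave open whether fluoro, methyl or an amine at this place would give a number nearer compound 1 or compound 3. They also leave open whether the remaining chloro group of compound 3 counts in the same way.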